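This account rests on a few compounds, and the source may have more. Where it says the series, first, only, none or still open, it means among the compounds named here.

Compound 1 `C[C@@H](O)[C@H]1C(=O)N2C(C(=O)OCOC(=O)O[C@H]3CCCc4ccccc43)=C(S[C@@H]3CN[C@H](C(=O)N(C)C)C3)[C@H](C)[C@H]12` is a prodrug-type ester of a carbapenem core, and in a physicochemical assay for metabolic stability, read by HPLC, at pH 7.4, tested at 100 uM (a higher number here means that the compound lasts longer, a lower number that the compound disappears faster), compound 1 gives 0.0233 h. Two close relatives have also been measured. Compound 2 `C[C@@H](O)[C@H]1C(=O)N2C(C(=O)OCOC(=O)O[C@@H]3CCc4ccccc43)=C(S[C@@H]3CN[C@H](C(=O)N(C)C)C3)[C@H](C)[C@H]12` carries a 2,3-dihydro-1H-inden-1-yl group in place of the 1,2,3,4-tetrahydronaphthalen-1-yl group on the oxygen next to the carbonyl group. For compound 2 this assay reports only a limit, < 0.0167 h, not a number. Compound 3 `C[C@@H](O)[C@H]1C(=O)N2C(C(=O)OCOC(=O)O[C@@H]3CCCc4ccccc43)=C(S[C@@H]3CN[C@H](C(=O)N(C)C)C3)[C@H](C)[C@H]12` has the same atoms and bonds as compound 1 and differs only in the configuration drawn at one saturated ring carbon; in this assay compound 3 gives 0.025 h. Among the two numbers shown, compound 1 and compound 3 sit together, and the step of a 1.1-fold higher number from compound 1 to compound 3 (0.03 log units; within the scatter) is within the scatter, which fits (the fact that compounds 1 and 3 differ only in the configuration as drawn). The step of an at least 1.3-fold lower number from compound 1 to compound 2 (0.14 log units; that floor lies within the scatter) and the step of an at least 1.4-fold higher number from compound 2 to compound 3 (0.17 log units; that floor lies within the scatter) are both floors, resting on (the limit of < 0.0167 h in this assay, at which 1 of the 3 values shown sits), and neither is beyond the scatter.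

Compound 4 `C[C@@H](O)[C@H]1C(=O)N2C(C(=O)OCOC(=O)O[C@@H]3CCCCc4ccccc43)=C(S[C@@H]3CN[C@H](C(=O)N(C)C)C3)[C@H](C)[C@H]12` differs from compound 1 by a group of 11 heavy atoms (11 carbon; one six-membered aromatic ring of carbon only, one seven-membered non-aromatic ring of carbon only) in place of a group of 10 heavy atoms (10 carbon; one six-membered non-aromatic ring of carbon only, one six-membered aromatic ring of carbon only), on an oxygen next to a carbonyl group. The measured steps all stay within the scatter, so no step beyond the scatter is expected here either. Compound 4 is therefore expected to give 0.025 h, within 0.012 h to 0.05 h, which means an expected step of a 1.1-fold higher number from compound 1 to compound 4 (0.03 log units; within the scatter).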

Compound 4, half-life: 0.45 h
Beside the measured number, compound 4's estimate is 18-fold (1.26 log units) below it, and the stated range ends below it.
By their numbers in this assay, from the lowest: compounds 1 and 3 (each within the scatter of the next); then compound 4. At a limit, below all of these: compound 2.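

Until compound 4, no measured change in the group on this oxygen went beyond the scatter in this assay, but the group with the seven-membered non-aromatic ring gives a 19-fold higher number from compound 1 to compound 4 (1.29 log units; beyond the scatter), and likewise an 18-fold higher number from compound 3 to compound 4 (1.26 log units; beyond the scatter). This shows that the position is not indifferent: the group with the seven-membered non-aromatic ring in place of 1,2,3,4-tetrahydronaphthalen-1-yl produces a large step, although the aromatic ring stays, no hydrogen-bond donors or acceptors appear and no net charge is added. The comparison with the five-membered ring gives an at least 26-fold higher number from compound 2 to compound 4 (1.43 log units; beyond the scatter), a floor rather than a full size, and compound 2 has only a limit, not a number: the limit of < 0.0167 h in this assay, at which 1 of the 4 values shown sits.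

The compounds shown give no cause for the large step, and they show the seven-membered group in only one drawn configuration, so it stays open whether the stereocentre matters with this ring as little as it did between the six-membered pair. They also leave open whether an eight-membered carbon ring, an open-chain phenylpropyl group or an amine on the ring would keep the higher number.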